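Isopropoxy to Ethoxy: Cytotoxicity Notes on Compound 4

The source may report more compounds than this note shows. Statements on the series, on what has been measured and on what is new or still open speak of the compounds shown alone.

Compound 1 `CCOC(=O)CCCCCOc1cccc(CN(C(=O)c2ccc(-c3ccc4ccccc4c3)cc2)C(C)C)c1`: in an ADME assay on HepG2 cells (Homo sapiens) for cytotoxicity, read by CellTiter-Glo and resazurin assay, with a stated time of 72 h (on this read-out lower numbers stand for an effect already at smaller amounts and higher numbers for an effect only at larger amounts of compound), compound 1 gives only the limit > 26000 nM.
Compound 2 `CCOC(=O)CCCCCOc1cccc(CN(C(=O)c2ccc(-c3cccnc3)cc2)C(C)C)c1`: in this assay compound 2 gives only the limit > 26000 nM.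
Compound 3 `CCOC(=O)CCCCCOc1cccc(CN(C(=O)c2ccc(-c3cccc(OC(C)C)c3)cc2)C(C)C)c1`: in this assay compound 3 gives only the limit > 26000 nM.

Compound 3 stands nowhere distinct on these numbers: its value is a limit, and the two further values shown are the same limit (the limit of > 26000 nM in this assay, at which 3 of the 3 values shown sit). The steps among the measured compounds are all hidden by that limit: a step that the two limits leave unreadable from compound 1 to compound 3, a step that the two limits leave unreadable from compound 2 to compound 3 and a step that the two limits leave unreadable from compound 1 to compound 2. None of them can be read as a size, and none concerns the change now in question.

Compound 4 `CCOC(=O)CCCCCOc1cccc(CN(C(=O)c2ccc(-c3cccc(OCC)c3)cc2)C(C)C)c1` differs from compound 3 only at the 3-isopropoxyphenyl group, where the change reads (hydrogen in place of methyl on a saturated chain carbon bound to an oxygen on an aromatic ring and a saturated chain carbon). Among the compounds with values here, no measured step bears on a hydrogen in place of methyl at this place, so the expectation rests on the three limits alone. Since every measured compound sits at the limit, compound 4 is expected to sit there too, with the step that the limit leaves unreadable from compound 3 to compound 4 expected to stay unreadable. For compound 4 the estimate in this assay is 30000 nM, within 15000 nM to 60000 nM.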

Compound 4, half-maximal effective concentration: > 22300 nM
Compound 4: no number, only a limit (the forecaster's own chance of this, stated with the estimate: 85%); the middle value is on the limit's open side.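

In this assay compound 4 gives only the limit > 22300 nM. Its steps from compound 1, compound 2 and compound 3 therefore cannot be read as sizes. The compounds shown leave open at what concentration any of these four compounds has an effect in this assay, and whether isopropoxy to ethoxy changes that concentration at all.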